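The compounds below may be only part of what the source reports. "The series", "measured", "known", "first", "only" and "open" are said of these compounds alone.

In a functional assay on DU-145 cells (Homo sapiens) for cytotoxicity, read by sulforhodamine B assay, with a stated time of 48 h (on this read-out higher numbers stand for weaker inhibition and lower numbers for stronger inhibition), compound 1 `C[C@H]1CC[C@@H]2[C@@H](OC(=O)[C@]23CC(c2ccc(N(C)C)cc2)=NO3)[C@]2(C)C(=O)C=C[C@@]12O` gives 4500 nM while compound 2 `COc1ccc(C2=NO[C@]3(C2)C(=O)O[C@@H]2[C@H]3CC[C@H](C)[C@]3(O)C=CC(=O)[C@@]23C)cc1OC` gives 84000 nM and holds the higher of the two numbers. Going by the values given here, the only measured step that bears on the next change is large: a 19-fold higher number from compound 1 to compound 2 (1.27 log units; beyond the scatter) for 3,4-dimethoxyphenyl in place of 4-(dimethylamino)phenyl. Compound 3 `COc1cc(C2=NO[C@]3(C2)C(=O)O[C@@H]2[C@H]3CC[C@H](C)[C@]3(O)C=CC(=O)[C@@]23C)ccc1O` differs from compound 2 by hydrogen in place of methyl on an oxygen on an aromatic ring in one place, hydrogen in place of methyl on an oxygen on an aromatic ring. With compound 2 at 84000 nM as the high point, a smaller step toward lower numbers is expected in this assay (a 2.1-fold lower number from compound 2 to compound 3 (0.32 log units; beyond the scatter)) for this smaller change. The estimated value for compound 3 is 40000 nM within a range from 10000 nM to 120000 nM on this read-out.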

Compound 3, half-maximal inhibitory concentration: 71000 nM
Estimate against measurement, compound 3: 1.8-fold (0.25 log units) below; the measured number falls inside the stated range.
By their numbers in this assay, from the lowest: compound 1; then compounds 3 and 2 (each within the scatter of the next).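

In this assay the change from methoxy to hydroxy on the aromatic ring gives a 1.2-fold lower number from compound 2 to compound 3 (0.07 log units; within the scatter) and so leaves this oxygen without a step that clears the scatter. Against the 4-(dimethylamino)phenyl group, the 4-hydroxy-3-methoxyphenyl group gives a 16-fold higher number from compound 1 to compound 3 (1.20 log units; beyond the scatter) in a step as large as the one seen for 3,4-dimethoxyphenyl. No evidence accounts for either step. Still open, going by these compounds, is whether a plain amino group or a morpholine in place of dimethylamino would hold the lower number of compound 1.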